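Swapping Methylamino for Methoxy on a Nucleoside Core

This account rests on a few compounds, and the source may have more. Where it says the series, first, only, none or still open, it means among the compounds named here.

Of the compounds shown here, two have been measured so far. Compound 1 `COc1ncnc2c1c(-c1ccoc1)cn2[C@@H]1O[C@H](CO)[C@@H](O)[C@H]1O` and compound 2 `CNc1ncnc2c1c(-c1ccco1)cn2[C@@H]1O[C@H](CO)[C@@H](O)[C@H]1O` were tested in a functional assay on HL-60 cells (Homo sapiens) for antiproliferative activity, read by XTT assay, with a stated time of 72 h; on this read-out lower numbers stand for stronger inhibition and higher numbers for weaker inhibition. In this assay compound 1 gives 150 nM. In this assay compound 2 gives 620 nM, the highest of the two numbers, and its gap to compound 1 lies beyond the usual scatter. Among the measured compounds shown here, these two compounds differ in two places at once, so no single step joins them. Compound 3 `COc1ncnc2c1c(-c1ccco1)cn2[C@@H]1O[C@H](CO)[C@@H](O)[C@H]1O` has not yet been measured. It differs from compound 2 in one place: methoxy in place of methylamino on an aromatic carbon. A move toward lower numbers of modest size is expected. In this assay the expected step is a 2.5-fold lower number from compound 2 to compound 3 (0.39 log units; beyond the scatter), because compound 1 with methoxy at the same place gives 150 nM. Compound 3 is therefore estimated at 250 nM, with a range from 100 nM to 600 nM.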

Compound 3, half-maximal inhibitory concentration: 100 nM
Beside the measured number, compound 3's estimate is 2.5-fold (0.40 log units) above it, within the range that was stated.
By their numbers in this assay, from the lowest: compounds 3 and 1 (each within the scatter of the next); then compound 2.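

With the furan-2-yl group held fixed, methoxy in place of methylamino on this aromatic carbon can now be read alone in this assay, and it gives a clear change (a 6.2-fold lower number from compound 2 to compound 3 (0.79 log units; beyond the scatter)). This exchange removes the one hydrogen-bond donor of the methylamino group while keeping the same number of heavy atoms, so the position responds to a small change. With methoxy in place, furan-2-yl in place of furan-3-yl leaves the numbers within the usual scatter (a 1.5-fold lower number from compound 1 to compound 3 (0.18 log units; within the scatter)), so that exchange shows no readable effect here. No measurement at hand explains the methoxy step. Still open, as far as these compounds go, is whether methylamino and methoxy differ by a similar amount when furan-3-yl sits on the core. From the compounds shown here alone, how a plain amine or a longer ethoxy chain would behave at this position also remains open.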